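The compounds below may be only part of what the source reports. "The series", "measured", "known", "first", "only" and "open" are said of these compounds alone.

Measured in a functional assay for inhibition, with Homo sapiens as the target; on this read-out lower numbers stand for stronger inhibition and higher numbers for weaker inhibition:
- compound 1 `O=C(NC[C@H](NS(=O)(=O)c1cccnc1)C(=O)O)c1cc2cc(CCC3CCNCC3)sc2s1`: 8 nM
- compound 2 `O=C(NC[C@H](NS(=O)(=O)c1cccnc1)C(=O)O)c1cc2cc(CC3CCNCC3)sc2s1`: 23 nM

Compound 2, at 23 nM, holds the higher of the two numbers in this assay. The next compound is compound 3 `O=C(NC[C@H](NS(=O)(=O)c1cccnc1)C(=O)O)c1cc2cc(CCCC3CCNCC3)sc2s1`, and its change from compound 2 is 2-(piperidin-4-yl)ethyl in place of piperidin-4-yl on a saturated chain carbon bound to an aromatic carbon. Here 2-(piperidin-4-yl)ethyl replaces piperidin-4-yl on a saturated chain carbon bound to an aromatic carbon.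

Among the compounds with values here, only one measured step bears on this: a 2.9-fold higher number from compound 1 to compound 2 (0.46 log units; beyond the scatter). It is modest and beyond the scatter, and it swaps (piperidin-4-yl)methyl for piperidin-4-yl at the same place. Compound 3 runs the opposite way from that step and carries a longer chain than compound 1 does. Within the data shown here, no measured compound has the 2-(piperidin-4-yl)ethyl group, so the data do not show whether the trend carries on that far. A modest move to a lower number is therefore expected, no larger than the measured step, and a result within the scatter of compound 2 remains possible.

The expected step is a 2.1-fold lower number from compound 2 to compound 3 (0.32 log units; beyond the scatter). The estimate for compound 3 is 11 nM, with an expected range of 4 nM to 30 nM.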

Compound 3, half-maximal inhibitory concentration: 21 nM
Beside the measured number, compound 3's estimate is 1.9-fold (0.28 log units) below it; measured number inside the range.
By their numbers in this assay, from the lowest: compound 1; then compounds 3 and 2 (each within the scatter of the next).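

Working notes on the chain at this position, read in this assay: the gain seen with (piperidin-4-yl)methyl does not extend to 2-(piperidin-4-yl)ethyl, since compound 3 and compound 2 cannot be told apart (a 1.1-fold lower number from compound 2 to compound 3 (0.04 log units; within the scatter)). Compound 1 stays apart from compound 3 (a 2.6-fold higher number from compound 1 to compound 3 (0.42 log units; beyond the scatter)), so across these three compounds the number does not follow chain length in one direction, and only the (piperidin-4-yl)methyl group of compound 1 stands out from the other two. Nothing available explains this response to chain length.

From the compounds shown here alone, whether a longer chain than that of compound 3 would leave the number level or shift it remains open. Going by these compounds, it is also open whether a primary amine at the chain end, in place of the piperidine ring, would show the same preference for the (piperidin-4-yl)methyl length.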